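Swapping the Furan for a Tolylethyl Chain

The source may report more compounds than this note shows. Statements on the series, on what has been measured and on what is new or still open speak of the compounds shown alone.

Measured compounds:
compound 1 `CC(C(=O)NCc1ccc(C(F)(F)F)nc1-c1ccc(N(C)C)cc1)c1ccc(NS(C)(=O)=O)c(F)c1` 3.2 nM
compound 2 `COc1ccc(-c2nc(C(F)(F)F)ccc2CNC(=O)C(C)c2ccc(NS(C)(=O)=O)c(F)c2)cc1OC` 25.6 nM
compound 3 `CC(C(=O)NCc1ccc(C(F)(F)F)nc1-c1ccco1)c1ccc(NS(C)(=O)=O)c(F)c1` 5.8 nM

Three compounds share one core and differ only in the group attached on an aromatic carbon of the ring that carries the trifluoromethyl group. In an assay on CHO cells for antagonist activity at transient receptor potential cation channel subfamily V member 1 (Homo sapiens), read by FLIPR (a lower number here means a stronger inhibitor, a higher number a weaker inhibitor), compound 3 gives 5.8 nM; it stands second of the three numbers, close to compound 1 and clearly apart from compound 2. The new compound 4 `Cc1ccc(CCc2nc(C(F)(F)F)ccc2CNC(=O)C(C)c2ccc(NS(C)(=O)=O)c(F)c2)cc1` carries the change (2-(4-methylphenyl)ethyl in place of furan-2-yl on an aromatic carbon). Within the data shown here, no measured pair exchanges an aromatic ring for a chain of this kind, so the bearing steps are only the ones at the same place: a 1.8-fold higher number from compound 1 to compound 3 (0.26 log units; within the scatter) and a 4.4-fold lower number from compound 2 to compound 3 (0.64 log units; beyond the scatter). These show that changes here can leave the number nearly unchanged or shift it modestly; compound 2 shows the larger shift. A shift of similar, modest size is therefore expected in this assay, more likely upward, giving a 2.6-fold higher number from compound 3 to compound 4 (0.41 log units; beyond the scatter) as the estimate. For compound 4 the expected value in this assay is 15 nM, within a range from 4 nM to 60 nM.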

Compound 4, inhibition constant: 0.6 nM
Estimate against measurement, compound 4: 25-fold (1.40 log units) above; the measured number lies below the stated range.
By their numbers in this assay, from the lowest: compound 4; then compounds 1 and 3 (each within the scatter of the next); then compound 2.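

In this assay, among these compounds, the earlier compounds carried only an aromatic ring attached directly at this place, so they could not show how a chain would behave here. The 2-(4-methylphenyl)ethyl chain gives a 9.7-fold lower number from compound 3 to compound 4 (0.99 log units; beyond the scatter) and a 5.3-fold lower number from compound 1 to compound 4 (0.73 log units; beyond the scatter) as well as a 43-fold lower number from compound 2 to compound 4 (1.63 log units; beyond the scatter) and so makes compound 4 the strongest inhibitor of the four, even though it has more heavy atoms than furan-2-yl and no hydrogen-bond acceptor. No measurement at hand gives a reason for this drop in the number.

The compounds shown leave open whether the gain comes from the ethyl link, the aromatic ring or its methyl group. A plain 2-phenylethyl group, a longer 3-phenylpropyl chain and a butyl chain with no ring could help separate these parts.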